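This account rests on a few compounds, and the source may have more. Where it says the series, first, only, none or still open, it means among the compounds named here.

Measured so far:
compound 1, `Cc1ccc(C(=O)NCN2CCC(c3cccc[n+]3[O-])CC2)cc1C`: 65%
compound 2, `COc1ccccc1C1CCN(CNC(=O)c2cccc(C)c2)CC1`: 55%

Both numbers come from a functional assay on HEK293 cells for agonist activity at D(4) dopamine receptor (Homo sapiens), read by FLIPR; a higher number here means a larger maximal response, a lower number a smaller maximal response. In this assay compound 1 gives 65% and compound 2 gives 55%. The two values lie within the usual scatter of each other, so neither compound can be set above the other; compound 1 holds the numerically higher of two figures that are, for practical purposes, alike.

Compound 3, `O=C(NCN1CCC(c2cccc[n+]2[O-])CC1)c1ccc(F)c(Cl)c1`, has not yet been measured in this assay. It is built from compound 1 by one exchange: 3-chloro-4-fluorophenyl in place of 3,4-dimethylphenyl on a carbonyl carbon. The ring that leaves and the ring that enters are each a six-membered aromatic ring of carbon only, each with eight heavy atoms and neither with hydrogen-bond donors, hydrogen-bond acceptors or net charge; the amide and the rest of the shared core of compound 1 stay as they are.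

Among the compounds with values here, no pair of measured compounds differs in a single place, so no measured step is available to guide the expectation. The change is confined to one aromatic ring at the amide end, and no step beyond the scatter is expected in either direction, a number 5 percentage points lower from compound 1 to compound 3 (within the scatter). Compound 3 is therefore estimated at 60%, with a range from 40% to 80%.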

Compound 3, largest response reached (reported as efficacy), in percent of the reference or control that the assay uses: 67%
The estimate for compound 3 lay 7 percentage points below the measured number, and the stated range covers the measured number.
By their numbers in this assay, from the lowest: compounds 2, 1 and 3 (each within the scatter of the next, the first and the last beyond it).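

In this assay, within the data shown here, putting 3-chloro-4-fluorophenyl in place of 3,4-dimethylphenyl on a carbonyl carbon gives a number 2 percentage points higher from compound 1 to compound 3 (within the scatter) and so provides the first measured comparison of compounds that differ in one place. At this position, an aromatic ring carrying one chlorine and one fluorine cannot be told apart from one carrying two methyl groups, at least within the usual scatter of the maximal response, and the exchange leaves the amide and the rest of the shared core untouched. No measurement available here explains why the two rings give indistinguishable results.

This single exchange keeps the same ring type and the same number of heavy atoms, so it says little about how much change the position can bear, for example with a plain phenyl ring, a pyridine ring, or a ring bearing a carboxylic acid or a trifluoromethyl group. It also leaves open whether the similarity would hold with either halogen alone, or with the same exchange made on a different core.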